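Swapping an open sulfone chain for a cyclic sulfone

The compounds below may be only part of what the source reports. "The series", "measured", "known", "first", "only" and "open" are said of these compounds alone.

Compound 1 `Cc1cc(OCCCN2CCCC2=O)cc(C)c1-c1cccc(COc2ccc3c(c2)OC[C@H]3CC(=O)O)c1`: 31 nM
Compound 2 `Cc1nc(C)c(COc2cc(C)c(-c3cccc(COc4ccc5c(c4)OC[C@H]5CC(=O)O)c3)c(C)c2)s1`: 12 nM
Compound 3 `CCS(=O)(=O)CCOc1cc(C)c(-c2cccc(COc3ccc4c(c3)OC[C@H]4CC(=O)O)c2)c(C)c1`: 37 nM

All three compounds share one core and differ only in the chain attached through an oxygen on the aromatic ring. They were measured in an assay on CHO cells for displacement of a labelled ligand from Free fatty acid receptor 1 (Homo sapiens), read by scintillation counting, with a stated time of 90 min, in the presence of a further agent that is not named here; on this read-out lower numbers stand for stronger inhibition and higher numbers for weaker inhibition. On these numbers compound 3 gives the highest value. One of its steps lies within the scatter: a 1.2-fold higher number from compound 1 to compound 3 (0.08 log units; within the scatter). The other lies beyond it: a 3.1-fold higher number from compound 2 to compound 3 (0.49 log units; beyond the scatter).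

Compound 4 `Cc1cc(OCC2(O)CCS(=O)(=O)CC2)cc(C)c1-c1cccc(COc2ccc3c(c2)OC[C@H]3CC(=O)O)c1` differs from compound 3 in one place: 4-hydroxy-1,1-dioxothian-4-yl in place of (ethylsulfonyl)methyl on a saturated chain carbon bound to an oxygen on an aromatic ring. The sulfur-bearing group is kept but folded into a six-membered ring that also carries a hydroxyl.

The measured steps that bear on this are the changes of the same side chain: a 1.2-fold higher number from compound 1 to compound 3 (0.08 log units; within the scatter), a 2.6-fold lower number from compound 1 to compound 2 (0.41 log units; beyond the scatter) and a 3.1-fold higher number from compound 2 to compound 3 (0.49 log units; beyond the scatter). They show that exchanging one chain end for another moves the number only modestly, and that the ethylsulfonyl chain and the pyrrolidinone chain sit within scatter of each other. Going by the values given here, no measured step adds a ring or a hydroxyl here, so the direction is uncertain. The expectation is therefore a small step, likely within the scatter: a 1.2-fold lower number from compound 3 to compound 4 (0.09 log units; within the scatter). Compound 4 is estimated at 30 nM, with a range from 12 nM to 80 nM.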

Compound 4, inhibition constant: 24 nM
Compound 4: middle estimate off by 1.3-fold (0.10 log units), on the high side, within the range that was stated.
By their numbers in this assay, from the lowest: compounds 2, 4, 1 and 3 (each within the scatter of the next, the first and the last beyond it).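

In this assay, folding the ethylsulfonyl chain into 4-hydroxy-1,1-dioxothian-4-yl, on a saturated chain carbon bound to an oxygen on an aromatic ring, gives a 1.5-fold lower number from compound 3 to compound 4 (0.19 log units; within the scatter) and so leaves the number within the usual scatter. Going by these compounds alone, this is the first step here that adds a six-membered ring and a hydroxyl, and this position accepts both with no change that can be told from scatter; the new group also sits close to the other two chains, with a 2.0-fold higher number from compound 2 to compound 4 (0.30 log units; within the scatter) and a 1.3-fold lower number from compound 1 to compound 4 (0.11 log units; within the scatter), even though compound 2 and compound 3 lie beyond the scatter of each other. No measurement shown here explains why the number stays so close after this larger group enters.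

As far as these compounds go, what remains open is whether the ring or the hydroxyl matters more, a question that a plain 1,1-dioxothian-4-yl group, with the ring and no hydroxyl, could separate. Also open, from the compounds shown here alone, is how a chain ending in an amine or a carboxylic acid would read in this assay on this same shared core.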